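From cyclopentyl to cyclohexyl on the shared core

The source may report more compounds than this note shows. Statements on the series, on what has been measured and on what is new or still open speak of the compounds shown alone.

Values in an in vivo ADME assay on the whole organism for metabolic stability, with Mus musculus as the target, at a dose of 5 mg/kg by the intravenous route; on this read-out lower numbers stand for a shorter-lived compound and higher numbers for a longer-lived compound:
Compound 1 `O=C1Nc2c(ccc(F)c2F)C1(c1ccc(O)cc1)c1ccc(F)cc1`: 2.1 h
Compound 2 `O=C1Nc2c(ccc(F)c2F)C1(c1ccc(O)cc1)c1cccs1`: 0.4 h
Compound 3 `O=C1Nc2c(ccc(F)c2F)C1(c1ccc(O)cc1)C1CCCC1`: 3.7 h

Compound 3 stands level, within the scatter, with compound 1 and well clear of compound 2. The measured steps at this position are a 1.8-fold higher number from compound 1 to compound 3 (0.25 log units; within the scatter), within the scatter, and a 5.3-fold lower number from compound 1 to compound 2 (0.72 log units; beyond the scatter) and a 9.3-fold higher number from compound 2 to compound 3 (0.97 log units; beyond the scatter), both beyond it. Among the compounds with values here, only the steps involving thiophen-2-yl are large, and no measured step joins two saturated rings. Compound 4 `O=C1Nc2c(ccc(F)c2F)C1(c1ccc(O)cc1)C1CCCCC1` carries cyclohexyl in place of cyclopentyl on a saturated ring carbon. No step beyond the scatter is expected in this assay. The expected step is a 1.2-fold lower number from compound 3 to compound 4 (0.06 log units; within the scatter). Compound 4 is estimated at 3.2 h, with an expected range of 1.5 h to 6.5 h.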

Compound 4, half-life: 1.6 h
The estimate for compound 4 lay 2.0-fold (0.30 log units) above the measured number; low and high end bracket the measured number.
By their numbers in this assay, from the lowest: compound 2; then compounds 4, 1 and 3 (each within the scatter of the next, the first and the last beyond it).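

In this assay, within the data shown here, the two saturated rings at this position are not interchangeable: cyclohexyl in place of cyclopentyl gives the first step beyond the scatter between such rings (a 2.3-fold lower number from compound 3 to compound 4 (0.36 log units; beyond the scatter)). Cyclohexyl stays clear of thiophen-2-yl (a 4.0-fold higher number from compound 2 to compound 4 (0.60 log units; beyond the scatter)), yet it stands level with 4-fluorophenyl (a 1.3-fold lower number from compound 1 to compound 4 (0.12 log units; within the scatter)). Nothing shown bears on why the two saturated rings differ. The compounds shown leave open whether cyclobutyl, an open chain such as isopropyl, or a piperidine ring would match compound 3 or fall towards compound 4.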